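From compound 2 to compound 3: aryl change

The source may hold more compounds than are shown below. What is called first, only, known or untested is meant among the compounds shown, and "the series" means these compounds.

Measured so far in a functional assay on OVCAR-3 cells (Homo sapiens) for inhibition, read by MTT assay, with a stated time of 24 h; a higher number here means a weaker inhibitor, a lower number a stronger inhibitor
- Compound 1 `CC1(C)[C@H]2CC[C@]1(C)N(Cc1cn(-c3ccc(F)cc3)nn1)C(=O)C2` gives 200 nM
- Compound 2 `Cc1ccccc1-n1cc(CN2C(=O)C[C@@H]3CC[C@@]2(C)C3(C)C)nn1` gives 150 nM

Among the measured compounds shown here, compound 2 stands within the scatter of compound 1, the only other measured compound. The open case is compound 3 `COc1cccc(-n2cc(CN3C(=O)C[C@@H]4CC[C@@]3(C)C4(C)C)nn2)c1` with 3-methoxyphenyl in place of 2-methylphenyl on an aromatic nitrogen. For the measured compounds named here, the one measured step at this place (a 1.3-fold lower number from compound 1 to compound 2 (0.12 log units; within the scatter)) puts 2-methylphenyl in place of 4-fluorophenyl and stays within the scatter, so no step beyond the scatter is expected in this assay in either direction. Going by the values given here, no measured compound carries 3-methoxyphenyl. The expected step is small (a 1.1-fold higher number from compound 2 to compound 3 (0.05 log units; within the scatter)). Compound 3 is expected at 170 nM with an estimated range from 70 nM to 400 nM for repeat measurements.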

Compound 3, half-maximal inhibitory concentration: 280 nM
For compound 3 the middle estimate is 1.6-fold (0.22 log units) below the measured one, and the stated range covers the measured number.
By their numbers in this assay, from the lowest: compounds 2, 1 and 3 (each within the scatter of the next).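

In this assay, 3-methoxyphenyl on the aromatic nitrogen adds one hydrogen-bond acceptor to the count for 2-methylphenyl and gives a 1.9-fold higher number from compound 2 to compound 3 (0.27 log units; within the scatter), while the change from 4-fluorophenyl gives a 1.4-fold higher number from compound 1 to compound 3 (0.15 log units; within the scatter). Among the compounds shown here, this position now holds three substituted phenyl groups, including one with an oxygen, and no pair of them separates beyond the scatter. No available evidence bears on this result.

Going by these compounds, whether an amine or a carboxylic acid on the phenyl ring would separate from these compounds remains open. So does replacing the phenyl ring with a longer chain.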